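Carbamoyl in place of sulfo on the anilide

The compounds below may be only part of what the source reports. "The series", "measured", "known", "first", "only" and "open" are said of these compounds alone.

Measured so far in a functional assay on CLL cells (Homo sapiens) for cytotoxicity, read by MTT assay, with a stated time of 48 h; a lower number here means that less compound is needed, a higher number that more compound is needed for the effect:
compound 1 `C=C(CC)C(=O)c1ccc(OCC(=O)Nc2ccc(C(=O)O)c(O)c2)c(Cl)c1Cl` — > 25000 nM
compound 2 `C=C(CC)C(=O)c1ccc(OCC(=O)Nc2ccc3cc(C(=O)O)ccc3c2)c(Cl)c1Cl` — 3700 nM
compound 3 `C=C(CC)C(=O)c1ccc(OCC(=O)Nc2ccc(S(=O)(=O)O)cc2)c(Cl)c1Cl` — > 25000 nM

Compound 1 gives > 25000 nM in this assay, and this is a limit of the assay rather than a number. For the measured compounds named here, compound 2 gives 3700 nM in this assay, the only value that is a number. Compound 3 gives > 25000 nM in this assay, again a limit and not a number. Going by the values given here, compound 3 therefore stands at the limit where two of the three values sit (the limit of > 25000 nM in this assay, at which 2 of the 3 values shown sit); no step between measured compounds is available from which to read off the size of any change.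

Compound 4 `C=C(CC)C(=O)c1ccc(OCC(=O)Nc2ccc(C(N)=O)cc2)c(Cl)c1Cl` is the next in the series. From compound 3 it differs by one change: carbamoyl in place of sulfo on an aromatic carbon. Whether this change moves the value off the limit cannot be read from the measured compounds, since none of the three shares a step with another. The expectation is that the step from compound 3 to compound 4 an at least 3.1-fold lower number from compound 3 to compound 4 (0.49 log units; beyond the scatter) runs downward, beyond the scatter, with a real chance that only a limit is reported again. Compound 4 is estimated at 8000 nM in this assay, within a range from 2000 nM to 30000 nM.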

Compound 4, half-maximal effective concentration: 3700 nM
Beside the measured number, compound 4's estimate is 2.2-fold (0.33 log units) above it; measured number inside the range.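

Carbamoyl in place of sulfo, on an aromatic carbon para to a large group, gives an at least 6.7-fold lower number from compound 3 to compound 4 (0.82 log units; beyond the scatter) in this assay, and this is the first step in the series tied to a single place. Compound 3 gives > 25000 nM, which is a limit of the assay and not a number, so the step is known only as a lower bound on its size. The earlier compounds shown here shared no step, whereas this pair shows that the group at this position alone can decide whether the core stays at the limit or yields a number. Compound 4 gives 3700 nM.

Two groups at one position cannot separate the loss of sulfo from a contribution of carbamoyl itself, and a nitrile or an acetyl group at the same place would be needed to tell these apart. How far the true step reaches also stays open, and the limit still covers part of the series: the limit of > 25000 nM in this assay, at which 2 of the 4 values shown sit.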